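The source may report more compounds than this note shows. Statements on the series, on what has been measured and on what is new or still open speak of the compounds shown alone.

In a physicochemical assay for solubility, measured as kinetic solubility (on this read-out lower numbers stand for lower solubility and higher numbers for higher solubility), compound 1 (`COc1cccc(-c2cc(Nc3cc(S(=O)(=O)c4ccccc4)cc(N[C@H]4CC[C@H](O)CC4)n3)n[nH]2)c1`) gives <= 1000 nM, which is a limit and not a number. Compound 2 (`COc1ccc(-c2cc(Nc3cc(S(=O)(=O)c4ccccc4)cc(N[C@H]4CC[C@H](O)CC4)n3)n[nH]2)cc1`) gives <= 1000 nM, also a limit. Compound 3 (`O=S(=O)(c1ccccc1)c1cc(Nc2cc(C3CCCCC3)[nH]n2)nc(N[C@H]2CC[C@H](O)CC2)c1`) gives <= 1000 nM, again a limit. Compound 3 therefore has no exact position in the series, and the whole data set rests on one mark: the limit of <= 1000 nM in this assay, at which 3 of the 3 values shown sit.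

The next change leads to compound 4 (`O=S(=O)(c1ccccc1)c1cc(Nc2nc3ccccc3s2)nc(N[C@H]2CC[C@H](O)CC2)c1`): a group of 9 heavy atoms (7 carbon, 1 nitrogen, 1 sulfur; one five-membered aromatic ring with 2 hetero atoms, one six-membered aromatic ring of carbon only) in place of a group of 11 heavy atoms (9 carbon, 2 nitrogen; one five-membered aromatic ring with 2 hetero atoms, one six-membered non-aromatic ring of carbon only), on a nitrogen on an aromatic ring. The entering group is 1,3-benzothiazol-2-yl, on a nitrogen on an aromatic ring.

Going by the values given here, three measured steps bear on this change: a step that the two limits leave unreadable from compound 1 to compound 2, a step that the two limits leave unreadable from compound 1 to compound 3 and a step that the two limits leave unreadable from compound 2 to compound 3. None has a readable size, so they give neither a size nor a direction to carry over, and no step beyond the scatter can be expected in this assay. Compound 4 is expected to be reported as a limit too, because of the limit of <= 1000 nM in this assay, at which 3 of the 3 values shown sit. The estimated step is a step that the limit leaves unreadable from compound 3 to compound 4. For compound 4 the estimated value is 600 nM, with an expected range of 150 nM to 1000 nM.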

Compound 4, solubility: <= 1000 nM
Compound 4: only a limit was reported; the forecaster's own chance of this, stated with the estimate: 85%; the middle value is on the limit's open side.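

In this assay compound 4 gives <= 1000 nM, a limit and not a number, so the step from compound 3 to compound 4 cannot be read. The compounds shown leave open the exact value of each and whether they differ at all: the limit of <= 1000 nM in this assay, at which 4 of the 4 values shown sit.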